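Sulfonamide aryl variation in a coumarin-triazole series

The compounds below may be only part of what the source reports. "The series", "measured", "known", "first", "only" and "open" are said of these compounds alone.

Measured so far in a functional assay on A549 cells (Homo sapiens) for inhibition, read by MTT assay, with a stated time of 72 h; a lower number here means a stronger inhibitor, a higher number a weaker inhibitor:
- compound 1 `O=c1cc(Cn2cc(CNS(=O)(=O)c3ccc(Cl)cc3)nn2)c2ccc(O)cc2o1`: 47900 nM
- compound 2 `O=c1cc(Cn2cc(CNS(=O)(=O)c3ccc(F)cc3Cl)nn2)c2ccc(O)cc2o1`: 91900 nM

For the measured compounds named here, compound 2 holds the highest of the two numbers so far; its nearest neighbour is compound 1, and the step of a 1.9-fold higher number from compound 1 to compound 2 (0.28 log units; within the scatter) lies within the scatter, so the two values cannot be ranked against each other.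

Compound 3 `O=c1cc(Cn2cc(CNS(=O)(=O)c3ccc([N+](=O)[O-])cc3)nn2)c2ccc(O)cc2o1` is not yet measured. The change from compound 2 to compound 3 is 4-nitrophenyl in place of 2-chloro-4-fluorophenyl on a sulfonyl sulfur. Going by the values given here, the only measured step touching this position is the one from compound 1 to compound 2, which swapped one substituted phenyl for another on the same sulfonyl sulfur without moving the number beyond the scatter. Among the compounds with values here, no measured step concerns a nitro-bearing aryl, so the bearing of that step on the present change is indirect: it shows only that one aryl exchange at this place left this assay unmoved.

On that basis no step beyond the scatter is expected from compound 2 to compound 3; the estimated step is a 1.4-fold lower number from compound 2 to compound 3 (0.15 log units; within the scatter). Compound 3 is accordingly expected at about 65000 nM, with a range from 25000 nM to 160000 nM.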

Compound 3, half-maximal inhibitory concentration: > 100000 nM
Compound 3: a limit, no number; the forecaster's own chance of this, stated with the estimate: 20%; at least 1.5-fold (0.18 log units) between middle value and limit.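

In this assay, compound 3 carries a limit of the assay and not a number: the limit of > 100000 nM in this assay, at which 1 of the 3 values shown sits.

Nitro in place of chloro on an aromatic carbon gives an at least 2.0-fold higher number from compound 1 to compound 3 (0.31 log units; beyond the scatter). For the compounds shown here, this is the first aryl exchange on the sulfonyl sulfur whose step clears the scatter, so the group on this phenyl can matter in this assay, which the earlier exchange did not show. The comparison with the 2-chloro-4-fluorophenyl compound settles less, at an at least 1.0-fold higher number from compound 2 to compound 3 (0.03 log units; that floor lies within the scatter), so that pair stays unranked and the change to 4-nitrophenyl has no readable size there.

No step shown lowers the number beyond the scatter, so it remains open whether any aryl on the sulfonyl sulfur can do so. Also open, from the compounds shown here alone, is how an amine or a carboxylic acid on this phenyl, or a plain alkyl chain in place of the phenyl, would read in this assay.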